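A few compounds are considered here, and "the series" means these few. Any claim that something is new, unique, unknown or untested is made for them only; others in the source may bear on it.

Measured compounds in a functional assay on HeLa S3 cells (Homo sapiens) for antiproliferative activity, read by XTT assay, with a stated time of 72 h; on this read-out lower numbers stand for stronger inhibition and higher numbers for weaker inhibition:
compound 1, `CSc1ncnc2c1c(-c1ccccc1)cn2[C@@H]1O[C@H](CO)[C@@H](O)[C@H]1O`: > 20000 nM
compound 2, `C#Cc1cn([C@@H]2O[C@H](CO)[C@@H](O)[C@H]2O)c2nc(C)nc(N)c12`: > 20000 nM
compound 3, `COc1ncnc2c1c(-c1ccccc1)cn2[C@@H]1O[C@H](CO)[C@@H](O)[C@H]1O`: > 20000 nM

Compound 1 gives only a limit in this assay, > 20000 nM, not a number. Compound 2 likewise gives only a limit, > 20000 nM. Compound 3 also sits at a limit, > 20000 nM. Within the data shown here, the one measured step, methoxy in place of methylsulfanyl on an aromatic carbon, a step that the two limits leave unreadable from compound 1 to compound 3, cannot be sized, since (the limit of > 20000 nM in this assay, at which 3 of the 3 values shown sit).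

Compound 4, `C#Cc1cn([C@@H]2O[C@H](CO)[C@@H](O)[C@H]2O)c2ncnc(SC)c12`, is not yet measured. It differs from compound 1 by ethynyl in place of phenyl on an aromatic carbon. Among the measured compounds shown here, no measured step bears directly on this change: compound 2 carries ethynyl with different groups on the core and sits at the limit, while compound 1 carries methylsulfanyl with phenyl and sits at the limit, so neither anchors the size of the step in this assay. With every neighbour at the limit, the expected outcome for compound 4 is another limit, and the estimated step of an at least 1.3-fold lower number from compound 1 to compound 4 (0.12 log units; that floor lies within the scatter) is therefore held wide. Compound 4 is estimated at 15000 nM, between 500 nM and 20000 nM.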

Compound 4, half-maximal inhibitory concentration: 110 nM
Compound 4: the middle estimate sits 140-fold (2.13 log units) above what was measured; measured number outside the range, below it.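

Ethynyl in place of phenyl on an aromatic carbon of the five-membered aromatic ring gives an at least 180-fold lower number from compound 1 to compound 4 (2.25 log units; beyond the scatter) in this assay, and this is the only step shown that can be read. Compound 1 gives > 20000 nM as a limit, so the printed size of the step is a floor and not a full measure. With methylsulfanyl held constant, the change at this one position separates a compound at the limit from one with a measured number, so this position can strongly alter the read-out.

On these data alone, how other groups at this position, such as a propyl chain, a nitrile or an amine, compare with ethynyl remains open. As far as these compounds go, whether methoxy in place of methylsulfanyl matters also remains open, and the step from compound 1 to compound 3 cannot be read: the limit of > 20000 nM in this assay, at which 3 of the 4 values shown sit.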